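The compounds below may be only part of what the source reports. "The series", "measured", "known", "first", "only" and "open" are said of these compounds alone.

Compound 1 `CC1(C)S[C@@H]2/C(=C\C(=O)c3ccccc3)C(=O)N2[C@H]1C(=O)OC(c1ccccc1)c1ccccc1` was tested in a functional assay on A-375 cells (Homo sapiens) for cytotoxicity, read by MTT assay, with a stated time of 48 h (a higher number here means a weaker inhibitor, a lower number a stronger inhibitor), where compound 1 gives 22800 nM. Of the two numbers measured, that of compound 1 is the highest. Compound 2 `CC1(C)S[C@@H]2/C(=C\C(=O)OC(c3ccccc3)c3ccccc3)C(=O)N2[C@H]1C(=O)OC(c1ccccc1)c1ccccc1` gives 9100 nM in this assay, a lower number that lies beyond the usual scatter. Compound 3 `CC1(C)S[C@@H]2/C(=C\C(=O)c3ccc4ccccc4c3)C(=O)N2[C@H]1C(=O)OC(c1ccccc1)c1ccccc1` is not yet measured. It differs from compound 1 by naphthalen-2-yl in place of phenyl on a carbonyl carbon. For the measured compounds named here, no measured pair shows this change, so the size of its effect is unknown. A modest step toward a lower number is expected, a 1.5-fold lower number from compound 1 to compound 3 (0.18 log units; within the scatter), though it may stay within the scatter. Compound 3 is therefore estimated at 15000 nM in this assay, within a range from 5000 nM to 45000 nM.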

Compound 3, half-maximal inhibitory concentration: 36500 nM
Estimate against measurement, compound 3: 2.4-fold (0.39 log units) below; measured number inside the range.
By their numbers in this assay, from the lowest: compound 2; then compounds 1 and 3 (each within the scatter of the next).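

In this assay, naphthalen-2-yl in place of phenyl on a carbonyl carbon gives a 1.6-fold higher number from compound 1 to compound 3 (0.20 log units; within the scatter). This position therefore accepts a second six-membered aromatic ring, and the four extra carbons bring no change that can be told from the scatter. Nothing available offers a reason for this outcome.

From the compounds shown here alone, it remains open whether an amine or a short alkyl chain in place of phenyl on this carbonyl carbon would shift the number beyond the scatter. Going by these compounds, the effect of naphthalen-1-yl also remains open.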